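Diaryl ether amides as Toll-like receptor 8 inhibitors

The source may report more compounds than this note shows. Statements on the series, on what has been measured and on what is new or still open speak of the compounds shown alone.

Working notes on a small set of diaryl ether compounds tested in an assay on HEK293 cells for inhibition of Toll-like receptor 8 (Homo sapiens), with a stated time of 16 h; a lower number here means a stronger inhibitor, a higher number a weaker inhibitor. Compound 1 `N#Cc1c(Cl)cccc1Oc1ccc(-c2nnco2)cc1` carries a nitrile and an oxadiazole and gives 1400 nM in this assay. Compound 2 `O=C(Nc1ccc(Oc2cc(C(F)(F)F)cc(C(F)(F)F)c2)cc1)c1cc(Cl)ccc1F` is an amide with a bis(trifluoromethyl)phenyl ether and gives 1110 nM in this assay; the two values lie within the usual scatter of one another, so no order between them can be claimed. Compound 3 `O=C(Nc1ccc(Oc2cc(C(F)(F)F)cc(C(F)(F)F)c2)cc1)c1cc(I)ccc1F` shares the amide and ether of compound 2 but bears an iodine in place of the chlorine; in this assay compound 3 gives "not determined" (no result reported), so no single number for it is available and its standing cannot be stated.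

Compound 4 `Nc1ccc(C(=O)Nc2ccc(Oc3cc(C(F)(F)F)cc(C(F)(F)F)c3)cc2)c(F)c1` is reached from compound 3 by the following change: 4-amino-2-fluorophenyl in place of 2-fluoro-5-iodophenyl on a carbonyl carbon. Among the measured compounds shown here, no measured step of this kind exists in the set, and the two nearest measured compounds sit close together, so the direction of the change cannot be read from the data. The step is expected to be modest, possibly in either direction, and within or only slightly beyond the scatter. Compound 4 is expected to give about 1500 nM in this assay, with a plausible range from 400 nM to 6000 nM.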

Compound 4, half-maximal inhibitory concentration: > 50000 nM
Compound 4 gave a limit, no number; the forecaster's own chance of this, stated with the estimate: 10%; middle value at least 33-fold (1.52 log units) from the limit.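

In this assay, among the compounds shown here, 4-amino-2-fluorophenyl in place of 5-chloro-2-fluorophenyl on a carbonyl carbon gives an at least 45-fold higher number from compound 2 to compound 4 (1.65 log units; beyond the scatter), the only step in the set that can be read, and it shows that the group on this carbonyl carbon cannot be exchanged freely while the rest of the amide and ether stays the same. Compound 4 stands at a limit of the assay rather than at a number, so the step has a lower bound and no exact size: the limit of > 50000 nM in this assay, at which 1 of the 4 values shown sits. The step from compound 3 to compound 4 cannot be read, as compound 3 has no reported result.

On these data alone, this single step changes the entering amine, the leaving halogen and the place of the substituent together, so it remains open which of these goes with the loss of inhibition. The compounds shown do not tell how 5-amino-2-fluorophenyl, 4-chloro-2-fluorophenyl or a ring bearing a carboxylic acid on the same carbonyl carbon would stand in this assay.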